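This account rests on a few compounds, and the source may have more. Where it says the series, first, only, none or still open, it means among the compounds named here.

Compound 1 `Cc1ccccc1OCCCCCn1ccc(=O)[nH]c1=O`: > 100000 nM, a limit. Compound 2 `O=c1ccn(CCCCCOc2ccc([N+](=O)[O-])cc2)c(=O)[nH]1`: 20000 nM. Compound 3 `O=c1ccn(CCCCCOc2ccc(Cl)cc2)c(=O)[nH]1`: > 100000 nM, a limit.

In an ADME assay on HEL cells (Homo sapiens) for cytotoxicity, read by microscopy (on this read-out lower numbers stand for higher toxicity in this test and higher numbers for lower toxicity in this test), compound 3 gives only a limit, > 100000 nM. Compound 1 also sits at a limit, > 100000 nM, so two of the three values rest at the limit of > 100000 nM in this assay, at which 2 of the 3 values shown sit. Within the data shown here, compound 2 is the one measured number, at 20000 nM, and an at least 5.0-fold higher number from compound 2 to compound 3 (0.69 log units; beyond the scatter) counts as at least modest. By contrast a step that the two limits leave unreadable from compound 1 to compound 3 cannot be read. Compound 4 `O=c1ccn(CCCCCOc2ccc(Br)cc2)c(=O)[nH]1` differs from compound 3 by bromo in place of chloro on an aromatic carbon. Among the measured compounds shown here, no measured step sets bromo against chloro here, so the two halogens are expected to lie close together. The step of a number no higher from compound 3 to compound 4 (the limit leaves the size open) is therefore expected to stay within the scatter. Compound 4 is expected to give 100000 nM, between 40000 nM and 250000 nM, most likely again as a limit.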

Compound 4, minimum cytotoxic concentration: 100000 nM
The estimate for compound 4 equals the measured number at the digits printed; the range from low to high includes it.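

In this assay compound 4 supplies a measured number for a halogen at this place, para to a large group. Bromo in place of nitro gives a 5.0-fold higher number from compound 2 to compound 4 (0.70 log units; beyond the scatter) and this step counts as modest. The bromo group thus gives a firm size for a change that chloro could only bound. Neither a number no higher from compound 3 to compound 4 (the limit leaves the size open) nor a number no higher from compound 1 to compound 4 (the limit leaves the size open) can be read because each starts from a limit: the limit of > 100000 nM in this assay, at which 2 of the 4 values shown sit.

On these data alone, whether bromo and chloro differ at all remains open. So does how an amine or a carboxylic acid at this place, or a longer chain, would read.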